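The compounds below may be only part of what the source reports. "The series", "measured", "known", "first", "only" and "open" are said of these compounds alone.

Values so far in a functional assay on HOP-92 cells (Homo sapiens) for inhibition, read by sulforhodamine B assay, with a stated time of 48 h; a lower number here means a stronger inhibitor of growth, a higher number a weaker inhibitor of growth

compound 1 `COc1cc(-c2nn(-c3cccc(NC(=O)c4cccc(C(F)(F)F)c4)c3)cc2-c2ccncc2)ccc1Cl` gives 555 nM
compound 2 `COc1cc(-c2nn(-c3cccc(NC(=O)Nc4cccc(C(F)(F)F)c4)c3)cc2-c2ccncc2)ccc1Cl` gives 557 nM
compound 3 `COc1cc(-c2nn(-c3cccc(NC(=O)c4ccc(Cl)c(C(F)(F)F)c4)c3)cc2-c2ccncc2)ccc1Cl` gives 665 nM

Compound 3 at 665 nM lies within the scatter of both other compounds, so it holds no distinct place among them. Compound 4 `COc1cc(-c2nn(-c3cccc(NC(=O)c4ccccc4)c3)cc2-c2ccncc2)ccc1Cl` carries phenyl in place of 4-chloro-3-(trifluoromethyl)phenyl on a carbonyl carbon and so loses both the chloro and the trifluoromethyl group. Only the chloro part has a measured counterpart, in the opposite direction: a 1.2-fold higher number from compound 1 to compound 3 (0.08 log units; within the scatter) is within the scatter. The step of a 1.0-fold higher number from compound 1 to compound 2 (0.00 log units; within the scatter) changes another part of the molecule and gives no direct guide. Among the measured compounds shown here, no measured compound lacks the trifluoromethyl group, so that part of the change is untested here. A modest rise in the number is expected, meaning weaker growth inhibition, though this expectation rests on little evidence. The estimate is a 1.4-fold higher number from compound 3 to compound 4 (0.13 log units; within the scatter) as an expected step of uncertain size. Compound 4 is expected at 900 nM within an estimated range from 400 nM to 2500 nM overall.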

Compound 4, concentration for 50% growth inhibition: 324 nM
The estimate for compound 4 lay 2.8-fold (0.44 log units) above the measured number, and the stated range ends above it.
By their numbers in this assay, from the lowest: compounds 4, 1, 2 and 3 (each within the scatter of the next, the first and the last beyond it).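

In this assay, among the compounds shown here, phenyl in place of 4-chloro-3-(trifluoromethyl)phenyl on a carbonyl carbon gives the first step at this position beyond the scatter (a 2.1-fold lower number from compound 3 to compound 4 (0.31 log units; beyond the scatter)), a modest one, so removing the chloro and trifluoromethyl groups together separates these two compounds. Each single change to compound 4 stays within the scatter: hydrogen in place of trifluoromethyl (a 1.7-fold lower number from compound 1 to compound 4 (0.23 log units; within the scatter)) and phenyl in place of (3-(trifluoromethyl)phenyl)amino (a 1.7-fold lower number from compound 2 to compound 4 (0.24 log units; within the scatter)), so growth inhibition in this range does not require either group on this ring. No measurement shown accounts for the step.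

Still open, going by these compounds, is how a chloro group alone on this phenyl would read, which would separate its contribution from that of trifluoromethyl. Also open, on these data alone, is whether an amine, a carboxylic acid or a saturated cyclohexyl ring on the carbonyl carbon would retain growth inhibition.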